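Lengthening the chain: from formyl to 2-oxopropyl

The source may hold more compounds than are shown below. What is called first, only, known or untested is meant among the compounds shown, and "the series" means these compounds.

Compound 1, `CCc1onc(NS(=O)(=O)c2ccc(C(C)(C)C)cc2)c1Sc1cccc(OC)c1`, gives 2800 nM in an assay on COS-7 cells for displacement of a labelled ligand from Endothelin receptor type B (Sus scrofa); on this read-out lower numbers stand for stronger inhibition and higher numbers for weaker inhibition.
Compound 2, `COc1cccc(Sc2c(NS(=O)(=O)c3ccc(C(C)(C)C)cc3)noc2C)c1`, gives 300 nM in this assay.
Compound 3, `COc1cccc(Sc2c(NS(=O)(=O)c3ccc(C(C)(C)C)cc3)noc2CCC=O)c1`, gives 500 nM in this assay.

Among these three, compound 3 stands second highest; its nearest neighbour is compound 2, to which the gap is within the scatter, while compound 1 lies furthest away, beyond the scatter. Compound 4, `COc1cccc(Sc2c(NS(=O)(=O)c3ccc(C(C)(C)C)cc3)noc2CCCC(C)=O)c1`, differs from compound 3 by one change: 2-oxopropyl in place of formyl on a saturated chain carbon, two bonds along the chain from an aromatic carbon.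

Two measured steps speak to this kind of change. Lengthening the chain on the core of compound 2 gave a 1.7-fold higher number from compound 2 to compound 3 (0.22 log units; within the scatter), a step within the scatter, so adding a carbonyl-bearing chain at this position cost little. Yet the shorter extension in compound 1 read far weaker, as a 9.3-fold lower number from compound 1 to compound 2 (0.97 log units; beyond the scatter) and a 5.6-fold lower number from compound 1 to compound 3 (0.75 log units; beyond the scatter) show, so chain length at this position is not indifferent. Growing the chain of compound 3 further while keeping a carbonyl is therefore expected to move the number only modestly, most likely slightly higher, in this assay. The step from compound 3 to compound 4 is estimated as a 1.4-fold higher number from compound 3 to compound 4 (0.15 log units; within the scatter). Compound 4 is expected to give about 700 nM, within a range from 250 nM to 2000 nM.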

Compound 4, half-maximal inhibitory concentration: 400 nM
The estimate for compound 4 lay 1.8-fold (0.24 log units) above the measured number, and the stated range covers the measured number.
By their numbers in this assay, from the lowest: compounds 2, 4 and 3 (each within the scatter of the next); then compound 1.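

In this assay, putting 2-oxopropyl in place of formyl on a saturated chain carbon, two bonds along the chain from an aromatic carbon, gave a 1.3-fold lower number from compound 3 to compound 4 (0.10 log units; within the scatter), so this further extension of the carbonyl-bearing chain left the reading within the scatter. The full 2-acetylethyl chain in place of hydrogen gave a 1.3-fold higher number from compound 2 to compound 4 (0.12 log units; within the scatter), which means that compound 2, compound 3 and compound 4 now read as one group, with two carbonyl-bearing chains of different length both staying level with compound 2. Compound 1 remains apart, with a 7.0-fold lower number from compound 1 to compound 4 (0.85 log units; beyond the scatter), so across these four compounds the number does not simply follow chain length, and compound 1 is the one that goes against any such trend.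

Nothing shown here gives a reason why the carbonyl-bearing chains read as they do on this read-out. Going by these compounds, whether a carboxylic acid or an amine at the end of the chain, or a still longer chain, would keep the number level with compound 2 stays open, as does how much of the reading depends on the carbonyl itself.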